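A few compounds are considered here, and "the series" means these few. Any claim that something is new, unique, unknown or untested is made for them only; others in the source may bear on it.

Measured so far:
Compound 1, `O=C(Nc1cc(-c2nc3ccccc3s2)ccc1Cl)c1cc([N+](=O)[O-])ccc1Cl`, in an ADME assay for permeability, using PAMPA, at pH 7.4; a higher number here means that the compound crosses the layer faster, a lower number that the compound crosses the layer more slowly: "below limit of detection" (no number reported)
Compound 2, `O=C(Nc1cc(-c2nc3ccccc3o2)ccc1F)c1cc([N+](=O)[O-])ccc1Cl`, in this assay: 214 10^-6 cm/s

Compound 1 gives only a limit of the assay, not a number, in this assay. Within the data shown here, compound 2 gives a number, 214 10^-6 cm/s, so the two compounds differ in more than one place and no step between them is known. Compound 3, `O=C(Nc1cccc(-c2nc3ccccc3s2)c1)c1cc([N+](=O)[O-])ccc1Cl`, has not been measured. It differs from compound 1 by hydrogen in place of chloro on an aromatic carbon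

Compound 1 has no number in this assay, only a limit. The size of the step to compound 3 therefore cannot be fixed; a shift upward, out of the undetected range, is thought possible but far from certain. Compound 3 is therefore expected to give about 30 10^-6 cm/s in this assay, within a wide range from 2 10^-6 cm/s to 300 10^-6 cm/s.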

Compound 3, apparent permeability in the ADME assay: 12 10^-6 cm/s
The estimate for compound 3 lay 2.5-fold (0.40 log units) above the measured number; measured number inside the range.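

Among these compounds, compound 1 has only a limit in the ADME assay, so no step from it to compound 3 can be read there. In a physicochemical assay for solubility, read by spectrophotometry, in phosphate buffer, measured as kinetic solubility, with a stated time of 18 h, at pH 7.4 (on this read-out higher numbers stand for higher solubility and lower numbers for lower solubility), compound 1 gives 100 nM and compound 3 gives 580 nM. Compound 1 and compound 3 leave open how large the change in the ADME assay is when hydrogen takes the place of chloro.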